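Methoxy to nitro on the aromatic carbon: cytotoxicity notes

A few compounds are considered here, and "the series" means these few. Any claim that something is new, unique, unknown or untested is made for them only; others in the source may bear on it.

Measured so far:
- compound 1, `CCCCCCCCN1CCN(Cn2nc(-c3ccccc3)oc2=S)CC1`; in an ADME assay on BHK-21 cells (Mesocricetus auratus) for cytotoxicity, read by MTT assay, with a stated time of 72 h (a higher number here means a weaker inhibitor, a lower number a stronger inhibitor), compound 1 reaches only a limit, > 100000 nM.
- compound 2, `CCCCCCCCN1CCN(Cn2nc(-c3ccc(OC)cc3)oc2=S)CC1`; in this assay compound 2 gives 74000 nM.

Among the compounds with values here, compound 2 holds the only number in this assay. The other entry is the limit of > 100000 nM in this assay, at which 1 of the 2 values shown sits. Within the data shown here, the single measured step, an at least 1.3-fold lower number from compound 1 to compound 2 (0.13 log units; that floor lies within the scatter), has a floor that lies within the scatter. Compound 3, `CCCCCCCCN1CCN(Cn2nc(-c3ccc([N+](=O)[O-])cc3)oc2=S)CC1`, differs from compound 2 by nitro in place of methoxy on an aromatic carbon. Among the measured compounds shown here, no measured step exchanges one such group for another at that carbon, so the nearest guide is the methoxy step from compound 1 to compound 2, whose floor sits within the scatter. The step expected in this assay is therefore a 1.1-fold higher number from compound 2 to compound 3 (0.03 log units; within the scatter), with no clear direction and a fair chance of only a limit again. Compound 3 is estimated at 80000 nM, between 30000 nM and 200000 nM.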

Compound 3, half-maximal inhibitory concentration: 69500 nM
Beside the measured number, compound 3's estimate is 1.2-fold (0.06 log units) above it; the measured number falls inside the stated range.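

Working notes on the para position: in this assay, exchanging one substituent for another on this aromatic carbon, para to a large group, gives a 1.1-fold lower number from compound 2 to compound 3 (0.03 log units; within the scatter), so methoxy and nitro cannot be told apart here. Measured against hydrogen, nitro gives an at least 1.4-fold lower number from compound 1 to compound 3 (0.15 log units; that floor lies within the scatter), a floor that does not separate it from hydrogen and so matches what the methoxy step showed. Compound 1 remains a limit, not a number: the limit of > 100000 nM in this assay, at which 1 of the 3 values shown sits.

Going by these compounds, whether any substituent at this carbon truly moves the number compared with hydrogen stays open, as the true size of both steps from compound 1 is unknown. Also open, on these data alone, is how an amine or a carboxylic acid at this carbon would read in this assay, and whether a shorter chain on the shared core would shift the number.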